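The compounds below may be only part of what the source reports. "The series", "measured", "known", "first", "only" and "open" are said of these compounds alone.

Working notes on the series, measured so far in a functional assay on DU-145 cells (Homo sapiens) for antiproliferative activity, read by MTT assay, with a stated time of 48 h; on this read-out lower numbers stand for stronger inhibition and higher numbers for weaker inhibition:

- compound 1 `COc1cccc(/C=C/C(=O)N2Cc3ccccc3[C@@H](OCc3ccccc3)[C@@H]2CO)c1OC`: 29900 nM
- compound 2 `COc1cc(/C=C/C(=O)N2Cc3ccccc3[C@@H](OCc3ccccc3)[C@@H]2CO)ccc1O`: 41300 nM

Only these two compounds have been measured. In this assay compound 2, at 41300 nM, stands level with compound 1 within the scatter, and both lie in the same weak range.

Next in line is compound 3 `O=C(/C=C/c1ccc([N+](=O)[O-])cc1)N1Cc2ccccc2[C@@H](OCc2ccccc2)[C@@H]1CO`, with 4-nitrophenyl in place of 4-hydroxy-3-methoxyphenyl on a double-bonded chain carbon bound to a double-bonded chain carbon. The shared core and the rest of the amide stay unchanged.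

Among the measured compounds shown here, one measured step bears on this change. a 1.4-fold higher number from compound 1 to compound 2 (0.14 log units; within the scatter) swaps the substituted phenyl group at the same place and leaves the number within the scatter. For the measured compounds named here, no measured compound carries a 4-nitrophenyl group, so this single step is weak guidance, and a wide range is warranted. No clear move beyond the scatter is expected in this assay, and no direction is favoured with any confidence. The expected step is small: a 1.2-fold lower number from compound 2 to compound 3 (0.07 log units; within the scatter). For compound 3 the estimated value is 35000 nM, with an expected range of 12000 nM to 90000 nM.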

Compound 3, half-maximal inhibitory concentration: 4070 nM
Compound 3: the middle estimate sits 8.6-fold (0.93 log units) above what was measured; measured number outside the range, below it.
By their numbers in this assay, from the lowest: compound 3; then compounds 1 and 2 (each within the scatter of the next).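

Notes on the phenyl group on a double-bonded chain carbon bound to a double-bonded chain carbon: in this assay this place proves able to move the number well beyond the scatter, which the earlier pair did not show. Replacing 4-hydroxy-3-methoxyphenyl with 4-nitrophenyl gives the large step (a 10-fold lower number from compound 2 to compound 3 (1.01 log units; beyond the scatter)), and replacing 2,3-dimethoxyphenyl with 4-nitrophenyl gives the modest one (a 7.3-fold lower number from compound 1 to compound 3 (0.87 log units; beyond the scatter)), whereas the exchange of the two oxygen-substituted phenyl groups stayed within the scatter (a 1.4-fold higher number from compound 1 to compound 2 (0.14 log units; within the scatter)). Nothing available explains why the 4-nitrophenyl group stands apart from the other two phenyl groups.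

From the compounds shown here alone, with a single nitro compound, it remains open whether the lower number belongs to the nitro group itself or would also appear with a nitrile, a trifluoromethyl group or an amine on the phenyl ring. Going by these compounds, it is equally open whether the gain would survive a change elsewhere, for instance a methyl ether in place of the benzyl ether on the shared core.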